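Trimming an amide substituent on a kinase inhibitor scaffold

The source may hold more compounds than are shown below. What is called first, only, known or untested is meant among the compounds shown, and "the series" means these compounds.

Measured compounds:
- compound 1 `CC[C@@H]1C(=O)N(C)c2cnc(Nc3ccc(S(=O)(=O)NCCO)cc3)nc2N1C1CCCC1`: 7.86 nM
- compound 2 `CC[C@@H]1C(=O)N(C)c2cnc(-n3ccc4cc(C(=O)NC(C)C)ccc43)nc2N1C1CCCC1`: 17.4 nM

Both compounds were tested in an assay for inhibition of serine/threonine-protein kinase PLK2 (Homo sapiens), read by FRET and Z'-LYTE, with a stated time of 1 h; on this read-out higher numbers stand for weaker inhibition and lower numbers for stronger inhibition. Compound 1 gives 7.86 nM in this assay, while compound 2 gives 17.4 nM. Of the two numbers, compound 2 stands at the higher one, and the gap to compound 1 is beyond the usual scatter, so compound 1 is the more potent of the pair.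

Compound 3 `CC[C@@H]1C(=O)N(C)c2cnc(-n3ccc4cc(C(N)=O)ccc43)nc2N1C1CCCC1` has not yet been measured in this assay. It differs from compound 2 in one place: hydrogen in place of isopropyl on an amide-type nitrogen. The isopropyl is cut away from the amide-type nitrogen, leaving the carbamoyl group bare. Among the measured compounds shown here, no measured pair shows this exact change, so its effect has to be guessed from the size of the group alone. Removing a small, uncharged group from the edge of the molecule is expected to move the number only a little, if at all, in either direction, most likely within the scatter.

For compound 3 the expected value is therefore 22 nM, with a likely range from 8 nM to 60 nM, which corresponds to an expected step of a 1.3-fold higher number from compound 2 to compound 3 (0.10 log units; within the scatter).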

Compound 3, half-maximal inhibitory concentration: 28.5 nM
Beside the measured number, compound 3's estimate is 1.3-fold (0.11 log units) below it, and the stated range covers the measured number.
By their numbers in this assay, from the lowest: compound 1; then compounds 2 and 3 (each within the scatter of the next).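

In this assay, cutting the isopropyl away from the amide-type nitrogen gives a 1.6-fold higher number from compound 2 to compound 3 (0.21 log units; within the scatter) and so leaves the two compounds indistinguishable on this read-out. Among the compounds shown here, this is the first measured step at this position, and it shows that all three carbon atoms of the isopropyl can be lost without the number moving beyond the usual scatter, so this group is not needed for the inhibition of PLK2 seen here. Nothing measured here accounts for this result, and the step on its own cannot say what the amide nitrogen or its substituent does in the assay.

From the compounds shown here alone, a single pair tests only removal, so it remains open whether a larger or differently built substituent on the same nitrogen, such as a longer chain, a cyclohexyl ring or a chain ending in an amine or a carboxylic acid, would leave the number equally unchanged or shift it beyond the scatter. The compounds shown also leave open whether the same change would behave alike on a different core or against other kinases.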